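A few compounds are considered here, and "the series" means these few. Any claim that something is new, unique, unknown or untested is made for them only; others in the source may bear on it.

Four analogues share one core; the group on the aromatic carbon of the fused six-membered ring varies. Compound 1 `CN(C)c1ncnc2[nH]cc(Sc3cccs3)c12` carries dimethylamino there and in a functional assay on HCT-116 cells (Homo sapiens), read by MTT assay, with a stated time of 3 days (on this read-out higher numbers stand for weaker inhibition and lower numbers for stronger inhibition), compound 1 gives 11000 nM. Compound 2 `Nc1ncnc2[nH]cc(Sc3cccs3)c12` carries amino instead, and in this assay compound 2 gives 22800 nM; the step of a 2.1-fold higher number from compound 1 to compound 2 (0.32 log units; beyond the scatter) is the only one in the set beyond the scatter. Compound 3 `c1csc(Sc2c[nH]c3ncnc(-c4cccs4)c23)c1` carries thiophen-2-yl at the same carbon, and in this assay compound 3 gives 13000 nM. Compound 3 stands second highest of the three numbers: its nearest neighbour is compound 1, a 1.2-fold higher number from compound 1 to compound 3 (0.07 log units; within the scatter), and its furthest is compound 2, a 1.8-fold lower number from compound 2 to compound 3 (0.24 log units; within the scatter), so compound 3 cannot be separated from either within the scatter.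

Compound 4 `COc1ncnc2[nH]cc(Sc3cccs3)c12` is not yet measured. The change is methoxy in place of thiophen-2-yl on an aromatic carbon. Within the data shown here, the steps that bear on it are the earlier exchanges at this carbon: a 1.2-fold higher number from compound 1 to compound 3 (0.07 log units; within the scatter) and a 1.8-fold lower number from compound 2 to compound 3 (0.24 log units; within the scatter), both within the scatter, and the modest 2.1-fold higher number from compound 1 to compound 2 (0.32 log units; beyond the scatter). A group with no ring and one hydrogen-bond acceptor entering for thiophen-2-yl is therefore expected to shift the number little, at most modestly toward weaker inhibition as compound 2 did; the expected step is a 1.2-fold higher number from compound 3 to compound 4 (0.06 log units; within the scatter). Compound 4 is estimated at 15000 nM, with a range from 7000 nM to 35000 nM.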

Compound 4, half-maximal inhibitory concentration: 17200 nM
Beside the measured number, compound 4's estimate is 1.1-fold (0.06 log units) below it; the measured number falls inside the stated range.
By their numbers in this assay, from the lowest: compounds 1, 3, 4 and 2 (each within the scatter of the next, the first and the last beyond it).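

In this assay, methoxy does not separate from any of the other groups at this aromatic carbon: a 1.3-fold higher number from compound 3 to compound 4 (0.12 log units; within the scatter), a 1.3-fold lower number from compound 2 to compound 4 (0.12 log units; within the scatter) and a 1.6-fold higher number from compound 1 to compound 4 (0.19 log units; within the scatter). Losing the five-membered aromatic ring and going from 5 heavy atoms to 2 therefore leaves no readable difference between thiophen-2-yl and methoxy, and compound 4 falls within the scatter of all three earlier compounds, so the only step beyond the scatter remains a 2.1-fold higher number from compound 1 to compound 2 (0.32 log units; beyond the scatter). No measurement at hand explains why this position tolerates such different groups with so little difference in the number.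

On these data alone, what a carboxylic acid, a piperazine or a longer chain such as butoxy would do at this carbon stays open, so it is unknown whether any group here can move the number clearly beyond the scatter. All four compounds also share the rest of the core, including the thiophen-2-yl group on sulfur, which leaves open whether this narrow spread would hold with a phenyl or a pyridine ring in that place.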